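Fluoro to trifluoromethyl: notes on compound 2

A few compounds are considered here, and "the series" means these few. Any claim that something is new, unique, unknown or untested is made for them only; others in the source may bear on it.

In an ADME assay on GES1 cells (Homo sapiens) for inhibition, read by MTT assay, with a stated time of 72 h (on this read-out lower numbers stand for stronger inhibition and higher numbers for weaker inhibition), compound 1 `Cc1cc(Nc2cc(-c3cccs3)[nH]n2)n2nc(SCc3ccc(Br)cc3)nc2n1` gives 38700 nM and compound 2 `Cc1cc(Nc2ccn(Cc3ccc(F)cc3)n2)n2nc(SCc3ccc(Br)cc3)nc2n1` gives 40500 nM. These two values lie within the scatter of each other, so compound 2 stands level with compound 1 among the numeric readings. Compound 3 `Cc1cc(Nc2cc(-c3ccccc3)[nH]n2)n2nc(SCC3CC3)nc2n1` reads > 50000 nM in this assay, and this is a limit of the assay, not a number.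

The next compound is compound 4 `Cc1cc(Nc2ccn(Cc3ccc(C(F)(F)F)cc3)n2)n2nc(SCc3ccc(Br)cc3)nc2n1`. It differs from compound 2 in one place, with trifluoromethyl in place of fluoro on an aromatic carbon, para to a large group (trifluoromethyl in place of fluoro on an aromatic carbon). The same difference reads as 4-fluorobenzyl to 4-(trifluoromethyl)benzyl.

For the measured compounds named here, no two measured compounds differ in one place only, so the series offers no measured step as a guide. In this assay no change beyond the scatter is expected, and the expectation is anchored on compound 2 at 40500 nM. The estimated change is a 1.1-fold lower number from compound 2 to compound 4 (0.04 log units; within the scatter). A result reported only as a limit also remains possible for compound 4, as already seen once in this set: the limit of > 50000 nM in this assay, at which 1 of the 3 values shown sits. For compound 4 the expected value is 37000 nM, with an estimated range from 19000 nM to 50000 nM.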

Compound 4, half-maximal inhibitory concentration: 30200 nM
For compound 4 the middle estimate is 1.2-fold (0.09 log units) above the measured one, within the range that was stated.
By their numbers in this assay, from the lowest: compounds 4, 1 and 2 (each within the scatter of the next). At a limit, above all of these: compound 3.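

For the compounds shown here, the step between these two compounds is the first that differs in one place only: in this assay, a 1.3-fold lower number from compound 2 to compound 4 (0.13 log units; within the scatter). Exchanging fluoro for trifluoromethyl on an aromatic carbon, para to a large group, therefore leaves the reading within the scatter, although one heavy atom leaves and four enter. Compound 4, like compound 2, gives a number and not a limit, so the 4-(trifluoromethyl)benzyl group keeps the series in the numeric range of this assay. Compound 3 differs from these compounds in more than one place and gives a limit, not a number: the limit of > 50000 nM in this assay, at which 1 of the 4 values shown sits.

With only fluoro and trifluoromethyl shown at this position, it remains open whether an amine, a nitrile or a carboxylic acid there would give a step beyond the scatter. As far as these compounds go, it also remains open whether a longer alkyl chain in place of the whole benzyl group would keep the reading a number or take it to a limit.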